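The compounds below may be only part of what the source reports. "The series", "measured", "known", "first", "only" and "open" are said of these compounds alone.

Measured in an ADME assay on microsomes from liver (Mus musculus) for metabolic stability (on this read-out lower numbers stand for slow clearance and higher numbers for fast clearance), where all three values are limits:
compound 1 `C[C@@H](C(=O)O)c1nn(Cc2cn3cc(OCC4CC4)c(Cl)cc3n2)c2ccccc2c1=O`: < 55 mL/min/kg.
compound 2 `COc1cc(OC)c(NC(=O)Cc2cn(CC(=O)O)c3ccccc23)cc1Cl`: < 60 mL/min/kg.
compound 3 `O=C(O)Cc1nn(Cc2cn3cc(OCC4CC4)c(Cl)cc3n2)c2ccccc2c1=O`: < 51.7 mL/min/kg.

Compound 3 has only a limit, < 51.7 mL/min/kg. The other two compounds also have only limits, so no order can be read among the three. Compound 4 `CCC(C(=O)O)c1nn(Cc2cn3cc(OCC4CC4)c(Cl)cc3n2)c2ccccc2c1=O` comes from compound 3 by ethyl in place of hydrogen on a saturated chain carbon bound to an aromatic carbon and a carbonyl carbon, the change from carboxymethyl to 1-carboxypropyl. Going by the values given here, the one measured step at this same carbon is a step that the two limits leave unreadable from compound 1 to compound 3, with hydrogen in place of methyl. Its size cannot be read, so it offers a precedent for change at this carbon but no magnitude to carry over. Among the compounds with values here, compound 2 differs from compound 3 in more than one place and has no step to it. In this assay no change beyond the scatter is therefore expected, and the expected step is a step that the limit leaves unreadable from compound 3 to compound 4. Another limit rather than a number is the likeliest report. For compound 4 the estimated clearance is 40 mL/min/kg, with an expected range from 20 mL/min/kg to 60 mL/min/kg.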

Compound 4, clearance: < 56.7 mL/min/kg
Compound 4 gave a limit, no number; the forecaster's own chance of this, stated with the estimate: 75%; the middle value is on the limit's open side.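

In this assay compound 4 gives only a limit, as do compound 1 and compound 3, so the steps to compound 4 from compound 3 and from compound 1 cannot be read. The compounds shown leave open the actual clearance of each compound, and with it the size of any change at this saturated chain carbon.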